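Swapping Dichlorophenyl for Phenyl in a Weak Cytotoxic Series

A few compounds are considered here, and "the series" means these few. Any claim that something is new, unique, unknown or untested is made for them only; others in the source may bear on it.

Three compounds have been measured so far:

Compound 1, `Cc1nc(Nc2ccccc2)sc1C(=O)/C=C/c1ccc(Cl)cc1`, tested in a functional assay on PC-3 cells (Homo sapiens) for cytotoxicity, read by MTT assay (on this read-out lower numbers stand for stronger inhibition and higher numbers for weaker inhibition), where compound 1 gives > 25000 nM, which is a limit of the assay rather than a number.
Compound 2, `Cc1nc(Nc2ccc(Cl)c(Cl)c2)sc1C(=O)/C=C/c1ccc(Cl)cc1`, where compound 2 gives > 25000 nM, again a limit of the assay.
Among the measured compounds shown here, compound 3, `COc1cc(/C=C/C(=O)c2sc(Nc3ccc(Cl)c(Cl)c3)nc2C)cc(OC)c1OC`, where compound 3 gives 19300 nM, the only true number among the three.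

Compound 2 and compound 1 differ in one place, (phenyl in place of 3,4-dichlorophenyl on a nitrogen on an aromatic ring), and the size of that step, a step that the two limits leave unreadable from compound 2 to compound 1, cannot be read because both ends sit at the limit (the limit of > 25000 nM in this assay, at which 2 of the 3 values shown sit). How the core of compound 2 differs from the core of compound 3 is not broken down here.

Compound 4, `COc1cc(/C=C/C(=O)c2sc(Nc3ccccc3)nc2C)cc(OC)c1OC`, is not yet measured. It differs from compound 3 by phenyl in place of 3,4-dichlorophenyl on a nitrogen on an aromatic ring, the same change already made between compound 2 and compound 1. Since that earlier step is unreadable and compound 3 gives a weak 19300 nM, the step from compound 3 to compound 4 is expected to be small, a 1.2-fold higher number from compound 3 to compound 4 (0.09 log units; within the scatter). Compound 4 is expected to give about 24000 nM in this assay, somewhere from 12000 nM to 50000 nM, with a fair chance that only a limit is reported.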

Compound 4, half-maximal inhibitory concentration: > 25000 nM
Compound 4: only a limit was reported (the forecaster's own chance of this, stated with the estimate: 55%); middle value at least 1.0-fold (0.01 log units) away from the limit.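

In this assay, putting phenyl in place of 3,4-dichlorophenyl on the core of compound 3 gives an at least 1.2-fold higher number from compound 3 to compound 4 (0.11 log units; that floor lies within the scatter) and this figure is only a floor, so the real step could be larger. Compound 4 gives > 25000 nM in this test, which is a limit of the assay and not a number. The same change on the core of compound 2 cannot be read, so nothing shows whether the change behaves alike on the two cores, because most of the values shown sit at one limit: the limit of > 25000 nM in this assay, at which 3 of the 4 values shown sit.

The compounds shown leave open whether a different group on the phenyl ring, such as an amine or a carboxylic acid, would give a clear number well away from that limit. They also leave open what a longer chain in place of the methyl on the shared core would do, and whether the anilino group would then give a readable step.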